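Branching the Side Chain on a Toll-like Receptor 8 Agonist

The source may hold more compounds than are shown below. What is called first, only, known or untested is meant among the compounds shown, and "the series" means these compounds.

Values in a functional assay on HEK293 cells for agonist activity at Toll-like receptor 8 (Homo sapiens), read by reporter gene assay; a higher number here means that more compound is needed for the effect, a lower number that less compound is needed:
compound 1 `CCCCCNc1oc2c(C)ncc(CO)c2c1Nc1ccccn1`: 5810 nM
compound 2 `Cc1ncc(CO)c2c(Nc3ccccn3)c(N)oc12`: "not active" (no number reported)
compound 3 `Cc1ncc(CO)c2c(Nc3ccccn3)c(NCc3ccccc3)oc12`: 4910 nM

Compound 1 holds the highest of the two numbers, yet its step to compound 3, a 1.2-fold lower number from compound 1 to compound 3 (0.07 log units; within the scatter), lies within the scatter, so the two are not distinguishable. Compound 2, which carries only a bare amino group at that position, shows no activity at all.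

Compound 4 `Cc1ncc(CO)c2c(Nc3ccccn3)c(NC(C)(C)CC(C)(C)C)oc12` differs from compound 1 in one place: 1,1,3,3-tetramethylbutyl in place of pentyl on a nitrogen on an aromatic ring. For the measured compounds named here, the single measured step at this nitrogen, a 1.2-fold lower number from compound 1 to compound 3 (0.07 log units; within the scatter), hardly moved the number, while compound 2 shows that some group on the nitrogen is needed. Compound 4 keeps such a group, so a step within the scatter is expected: a 1.1-fold lower number from compound 1 to compound 4 (0.02 log units; within the scatter). Compound 4 is therefore estimated at 5500 nM, within a range of 1800 nM to 17000 nM.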

Compound 4, half-maximal effective concentration: "not active" (no number reported)
For compound 4 the study gives words and no number; no gap can be computed for the estimate.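

For the compounds shown here, compound 4 is reported in this assay as not active, without a number, so no step from compound 1 to compound 4 can be read. The compounds shown leave open why 1,1,3,3-tetramethylbutyl gives this result where pentyl gives a number, and nothing measured here bears on that.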